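A few compounds are considered here, and "the series" means these few. Any claim that something is new, unique, unknown or untested is made for them only; others in the source may bear on it.

Measured compounds:
compound 1 `Cc1ccc(CNC(=O)c2nn(-c3ccc(F)cc3)c(CC[C@@H](O)C[C@@H](O)CC(=O)O)c2C(C)C)cc1`, 2.5 nM
compound 2 `CC(C)c1c(C(=O)N(C)Cc2cccc(F)c2)nn(-c2ccc(F)cc2)c1CC[C@@H](O)C[C@@H](O)CC(=O)O`, 4.1 nM
compound 3 `CC(C)c1c(C(=O)N2CCCCC2)nn(-c2ccc(F)cc2)c1OC[C@@H](O)C[C@@H](O)CC(=O)O`, 47 nM

In an assay on microsomes from liver for inhibition of 3-hydroxy-3-methylglutaryl-coenzyme A reductase (Rattus norvegicus) (on this read-out lower numbers stand for stronger inhibition and higher numbers for weaker inhibition), compound 3 stands highest of the three numbers shown; compound 2 sits nearest and compound 1 is furthest, both gaps beyond the scatter. Compound 4 `CC(C)c1c(C(=O)N(C)Cc2ccc(F)cc2)nn(-c2ccc(F)cc2)c1OC[C@@H](O)C[C@@H](O)CC(=O)O` keeps the core of compound 3 and differs only in (4-fluorobenzyl)(methyl)amino in place of piperidin-1-yl on a carbonyl carbon. For the measured compounds named here, the one step measured on a carbonyl carbon, a 1.6-fold higher number from compound 1 to compound 2 (0.21 log units; within the scatter), exchanged one benzyl amide for another and stayed within the scatter; no measured pair exchanges piperidin-1-yl for a benzyl amide. Because compound 1 gives 2.5 nM and compound 2 gives 4.1 nM while compound 3 gives 47 nM, a lower number is expected for compound 4, a step of a 3.9-fold lower number from compound 3 to compound 4 (0.59 log units; beyond the scatter). Compound 4 is estimated at 12 nM, between 4 nM and 35 nM.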

Compound 4, half-maximal inhibitory concentration: 18 nM
Compound 4: the middle estimate sits 1.5-fold (0.18 log units) below what was measured, and the stated range covers the measured number.
By their numbers in this assay, from the lowest: compounds 1 and 2 (each within the scatter of the next); then compound 4; then compound 3.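

In this assay, for the compounds shown here, the change on this carbonyl carbon is the first to lie beyond the scatter, a 2.6-fold lower number from compound 3 to compound 4 (0.42 log units; beyond the scatter), though it is modest. The position therefore separates piperidin-1-yl from (4-fluorobenzyl)(methyl)amino, whereas the earlier exchange of one benzyl amide for another did not separate its two groups. No measurement bearing on the reason for this difference is available. From the compounds shown here alone, it remains open whether the benzyl ring, its fluorine or the methyl on the amide nitrogen accounts for the step. Going by these compounds, how morpholin-4-yl or dimethylamino would read on this carbonyl carbon also remains open.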